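This account rests on a few compounds, and the source may have more. Where it says the series, first, only, none or still open, it means among the compounds named here.

Working notes on a short series built on one shared core. In a functional assay on SMMC-7721 cells (Homo sapiens) for cytotoxicity, read by MTT assay, with a stated time of 72 h (on this read-out higher numbers stand for weaker inhibition and lower numbers for stronger inhibition), compound 1 `CC(C)=C1C(=O)N(c2ccc(Cl)cc2)N(c2ccc(Cl)cc2)C1=O` gives 45600 nM. In this assay compound 2 `O=C1C(=Cc2ccc(F)cc2)C(=O)N(c2ccc(Cl)cc2)N1c1ccc(Cl)cc1` gives 23300 nM. Among the measured compounds shown here, these two values lie within the usual scatter of each other, so compound 2 stands with compound 1 on the numbers so far, and the pair cannot be ranked.

Compound 3 `COc1cc(C=C2C(=O)N(c3ccc(Cl)cc3)N(c3ccc(Cl)cc3)C2=O)ccc1O` has not yet been measured in this assay. Its difference from compound 2 is 4-hydroxy-3-methoxyphenyl in place of 4-fluorophenyl on a double-bonded chain carbon bound to a double-bonded ring carbon. For the measured compounds named here, no pair of measured compounds differs in one place only, so the series offers no direct precedent for this change. Going by the values given here, with only two values in hand, both within the scatter of each other, no step beyond the scatter is expected in this assay, and neither direction is favoured. The estimated change is a 1.2-fold lower number from compound 2 to compound 3 (0.07 log units; within the scatter). For compound 3 the expected value is an estimated 20000 nM, with an expected range of 7000 nM to 50000 nM.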

Compound 3, half-maximal inhibitory concentration: 64900 nM
Beside the measured number, compound 3's estimate is 3.2-fold (0.51 log units) below it; the whole stated range lies below it.
By their numbers in this assay, from the lowest: compounds 2, 1 and 3 (each within the scatter of the next, the first and the last beyond it).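

Among the compounds shown here, this is the first step that can be read at a single place. In this assay the change brings a 2.8-fold higher number from compound 2 to compound 3 (0.44 log units; beyond the scatter) and shows that, on a double-bonded chain carbon bound to a double-bonded ring carbon, the read-out responds to the group carried there, with 4-hydroxy-3-methoxyphenyl giving weaker inhibition than 4-fluorophenyl by a modest margin. The entering group has 9 heavy atoms against 7, with 1 hydrogen-bond donor and 2 hydrogen-bond acceptors where the leaving group has none, but no measurement available here explains the step or ties it to any one of these differences.

On these data alone, the hydroxy and methoxy groups enter together in compound 3, so the part each one plays in the step stays open, as does the effect of removing the fluorine on its own. Also open, as far as these compounds go, is how a dimethylamino group or a carboxylic acid on this aromatic ring, or a longer chain in place of the ring, would read in this assay against compound 2 and compound 3.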